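A few compounds are considered here, and "the series" means these few. Any claim that something is new, unique, unknown or untested is made for them only; others in the source may bear on it.

In a functional assay on Caco-2 cells (Homo sapiens) for inhibition, read by MTT assay, with a stated time of 48 h (a higher number here means a weaker inhibitor, a lower number a stronger inhibitor), compound 1 `COc1cc(/C=N/Nc2nc(-c3ccc(C(F)(F)F)cc3)cs2)c(Br)c(Br)c1OC` returns only a limit of the assay, > 100000 nM, so where it stands on the number scale is not fixed (the limit of > 100000 nM in this assay, at which 1 of the 3 values shown sits). Compound 2 `COc1cc(/C=N/Nc2nc(-c3cccc(Br)c3)cs2)cc(Br)c1OC` gives 43400 nM in this assay, and compound 3 `COc1ccccc1-c1csc(N/N=C/c2ccc(F)c(F)c2)n1` gives 25200 nM. Compound 4 `COc1cc(/C=N/Nc2nc(-c3ccc(F)c(F)c3)cs2)c(Br)c(Br)c1OC` has yet to be measured in this assay; it differs from compound 1 by 3,4-difluorophenyl in place of 4-(trifluoromethyl)phenyl on an aromatic carbon, the rest of the structure unchanged. For the measured compounds named here, no two measured compounds differ in one place, so the size of this step has no measured counterpart. Compound 4 is expected to come in at 60000 nM, within 20000 nM to 150000 nM. The step expected an at least 1.6-fold lower number from compound 1 to compound 4 (0.22 log units; that floor lies within the scatter) is a modest move toward a stronger inhibitor, with a real chance that the assay again reports only a limit.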

Compound 4, half-maximal inhibitory concentration: 22800 nM
Estimate against measurement, compound 4: 2.6-fold (0.42 log units) above; measured number inside the range.
By their numbers in this assay, from the lowest: compounds 4, 3 and 2 (each within the scatter of the next). At a limit, above all of these: compound 1.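

At this position, on an aromatic carbon next to the ring nitrogen, this assay gives a first one-place comparison: 3,4-difluorophenyl in place of 4-(trifluoromethyl)phenyl produces an at least 4.3-fold lower number from compound 1 to compound 4 (0.64 log units; beyond the scatter). With the rest of the structure unchanged, this aryl exchange alone brings a measurable number. The true size of the step stays open, as the value for compound 1 is only a limit: the limit of > 100000 nM in this assay, at which 1 of the 4 values shown sits.

A single pair cannot separate the removal of trifluoromethyl from the arrival of the two fluorines. As far as these compounds go, how a phenyl carrying an amine or a carboxylic acid would read at this position also remains open.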